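The source may report more compounds than this note shows. Statements on the series, on what has been measured and on what is new or still open speak of the compounds shown alone.

Of the compounds shown here, three built on one shared core have been tested in a functional assay on PBM cells (Homo sapiens) for cytotoxicity (a higher number here means a weaker inhibitor, a lower number a stronger inhibitor), and all three sit at the same edge of what the assay can read. Compound 1 `Nc1ncnc2c1ncn2[C@H]1C[Se][C@@H](CO)O1` gives > 100000 nM in this assay, which is a limit of the assay and not a number. Compound 2 `OC[C@H]1O[C@@H](n2cnc3c(O)ncnc32)C[Se]1` gives > 100000 nM in this assay, again a limit. Compound 3 `Nc1ncnc2c1ncn2[C@@H]1C[Se][C@@H](CO)O1` gives > 100000 nM in this assay, also a limit. Compound 3 therefore stands on a limit only and has no number of its own.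

Two steps connect the measured compounds: the step from compound 1 to compound 2 is a step that the two limits leave unreadable from compound 1 to compound 2, and the step from compound 1 to compound 3 is a step that the two limits leave unreadable from compound 1 to compound 3. Neither size can be read because of the limit of > 100000 nM in this assay, at which 3 of the 3 values shown sit, and the second step is a change of drawn configuration only, as shown by the fact that compounds 1 and 3 differ only in the configuration as drawn.

Compound 4 `OC[C@H]1O[C@H](n2cnc3c(O)ncnc32)C[Se]1` differs from compound 3 by hydroxy in place of amino on an aromatic carbon. Among the compounds with values here, this is the same kind of change as the one from compound 1 to compound 2, whose size stayed hidden, so no direction beyond the scatter can be foreseen. Compound 4 is estimated to give 200000 nM in this assay, within a range from 60000 nM to 1000000 nM. The expected step is a step that the limit leaves unreadable from compound 3 to compound 4.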

Compound 4, half-maximal inhibitory concentration: > 100000 nM
Compound 4 ended at the assay's limit; the forecaster's own chance of this, stated with the estimate: 85%; the middle value does not contradict the limit.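

Neither the step between compound 3 and compound 4 nor the step between compound 2 and compound 4 can be read, because all these compounds stop at the same edge of the assay: the limit of > 100000 nM in this assay, at which 4 of the 4 values shown sit.

The compounds shown leave open whether hydroxy in place of amino, or a change in configuration as drawn, alters the result in this assay at all.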